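Adding a methyl to compound 2's oxygen ring

The source may hold more compounds than are shown below. What is called first, only, known or untested is meant among the compounds shown, and "the series" means these compounds.

Measured in a functional assay on the whole organism (stomach) for inhibition, with Rattus norvegicus as the target; a higher number here means that more compound is needed for the effect, a lower number that less compound is needed:
- compound 1 `O=C(O)CCC/C=C1\CC2C[C@@H](O)[C@H](/C=C/[C@@H](O)c3ccc4c(c3)OCCO4)C2C1` gives > 0.3 mg/kg (a limit of the assay, not a number)
- compound 2 `O=C(O)CCC/C=C1\CC2C[C@@H](O)[C@H](/C=C/[C@@H](O)C3COc4ccccc4O3)C2C1` gives 0.0045 mg/kg
- compound 3 `COc1ccc2c(c1)OCC([C@H](O)/C=C/[C@@H]1C3C/C(=C/CCCC(=O)O)CC3C[C@H]1O)O2` gives 0.0021 mg/kg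

Compound 2 has the higher of the two actual numbers, so more of it is needed than of compound 3. Compound 1 reports only a limit.

Compound 4 `CC1([C@H](O)/C=C/[C@@H]2C3C/C(=C/CCCC(=O)O)CC3C[C@H]2O)COc2ccccc2O1` differs from compound 2 at a single place: methyl in place of hydrogen on a saturated ring carbon. In words, this is methyl in place of hydrogen on a saturated ring carbon.

Among the measured compounds shown here, two measured steps bear on this change, though neither makes it exactly. The first is a 2.1-fold lower number from compound 2 to compound 3 (0.33 log units; beyond the scatter), a modest step that places methoxy in place of hydrogen on an aromatic carbon. It is the closest guide to adding one small group, so a small change is expected here too. The second is an at least 66-fold lower number from compound 1 to compound 2 (1.82 log units; beyond the scatter), a large step that swaps 2,3-dihydro-1,4-benzodioxin-6-yl for 2,3-dihydro-1,4-benzodioxin-2-yl. It warns that this part of the molecule can matter greatly, so the range stays wide, especially toward higher numbers.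

The expected change is small, leaning slightly upward: a 1.6-fold higher number from compound 2 to compound 4 (0.19 log units; within the scatter). In this assay the estimated value for compound 4 is 0.007 mg/kg, with an expected range from 0.0015 mg/kg to 0.05 mg/kg.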

Compound 4, dose for half-maximal effect: 0.0142 mg/kg
Estimate against measurement, compound 4: 2.0-fold (0.31 log units) below; measured number inside the range.
By their numbers in this assay, from the lowest: compound 3; then compound 2; then compound 4. At a limit, above all of these: compound 1.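

In this assay, the saturated ring carbon of the six-membered non-aromatic ring with 2 oxygen responds to the addition of a single carbon: a 3.2-fold higher number from compound 2 to compound 4 (0.50 log units; beyond the scatter). The earlier steps changed where this ring is attached and added methoxy on an aromatic carbon, whereas this is the first change shown on the saturated ring carbon itself, and it moves the number in the opposite direction to the methoxy step, with compound 4 still active at 0.0142 mg/kg. The data shown give no measured property that would explain this modest rise, so its cause remains unknown.

The compounds shown leave open how the number responds to other groups on this saturated ring carbon, such as ethyl, a longer chain, fluorine or a hydroxyl group, and so whether the rise continues as the added group grows. They also leave open what happens when this methyl and the methoxy of compound 3 are present in one molecule, since their two opposite steps were each seen alone.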